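Replacing Allylamino with Methyl(propyl)amino: An Expected Outcome

The source may report more compounds than this note shows. Statements on the series, on what has been measured and on what is new or still open speak of the compounds shown alone.

Of the compounds shown here, three sharing one core have been measured in an assay for inhibition of acid-sensing ion channel 3 (Homo sapiens), read by patch clamp, tested at 20 uM; a higher number here means more inhibition at the concentration tested (going by the name of the read-out), a lower number less inhibition. Compound 1 `C=CCNc1nc(N)c(C(=O)N=C(N)N)nc1Cl` gives 78% and stands lowest of the three. Compound 2 `NC(N)=NC(=O)c1nc(Cl)c(NCc2ccc(Cl)cc2)nc1N` gives 97% and compound 3 `NC(N)=NC(=O)c1nc(Cl)c(NCC2CCCCC2)nc1N` gives 96%; the steps of a number 19 percentage points higher from compound 1 to compound 2 (beyond the scatter) and a number 18 percentage points higher from compound 1 to compound 3 (beyond the scatter) are both beyond the scatter, while a number 1 percentage points lower from compound 2 to compound 3 (within the scatter) is within it.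

Compound 4 `CCCN(C)c1nc(N)c(C(=O)N=C(N)N)nc1Cl` is not yet measured. It differs from compound 1 by methyl(propyl)amino in place of allylamino on an aromatic carbon. Going by the values given here, none of the measured steps directly bears on this change: each of them alters the group on the saturated chain carbon while keeping the allylamino nitrogen and its hydrogen, whereas here the hydrogen-bond donor leaves and a methyl group enters on the nitrogen itself. The measured steps only show that, when the group on the saturated chain carbon is varied, the number in this assay is higher or level. Among the compounds with values here, with no closer precedent, the expected step of a number 3 percentage points lower from compound 1 to compound 4 (within the scatter) is none beyond the scatter, so compound 4 is estimated at 75%, within 50% to 95%.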

Compound 4, a percentage reported as inhibition, at one concentration (the size of the read-out at that concentration, not a potency): 91%
For compound 4 the middle estimate is 16 percentage points below the measured one, and the stated range covers the measured number.
By their numbers in this assay, from the lowest: compound 1; then compounds 4, 3 and 2 (each within the scatter of the next).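

In this assay, methyl(propyl)amino in place of allylamino on the aromatic carbon next to the ring nitrogen gives a number 13 percentage points higher from compound 1 to compound 4 (beyond the scatter), the first change shown on the nitrogen itself. The hydrogen-bond donor of allylamino is therefore not required at this position for this level of inhibition, although the same step also removes the double bond and adds a carbon, so the pair cannot separate these changes. No supporting measurement is available to explain this step.

Propylamino and methyl(allyl)amino would show whether the methyl group on the nitrogen or the propyl chain accounts for the step. The compounds shown also leave open how a cyclic amine such as pyrrolidine or morpholine, or a larger group such as methyl(benzyl)amino, behaves at this position.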